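The source may hold more compounds than are shown below. What is called first, only, known or untested is meant among the compounds shown, and "the series" means these compounds.

Measured so far:
Compound 1 `COc1cc(/C=C2\C(=O)Nc3ccccc32)ccc1OCCCN1CCN(c2ncccc2C(F)(F)F)CC1` — in a functional assay on BT-549 cells (Homo sapiens) for cytotoxicity, read by MTT assay, with a stated time of 48 h (on this read-out higher numbers stand for weaker inhibition and lower numbers for stronger inhibition), compound 1 gives only a limit, > 20000 nM.
Compound 2 `COc1cc(/C=C2\C(=O)Nc3ccc(Cl)cc32)ccc1OCCCN1CCN(c2ncccc2C(F)(F)F)CC1` — in this assay compound 2 gives 1530 nM.

Compound 2 thus holds the only number shown; the other value is a limit. The step of an at least 13-fold lower number from compound 1 to compound 2 (1.11 log units; beyond the scatter) is itself a lower bound because of the limit of > 20000 nM in this assay, at which 1 of the 2 values shown sits. Compound 3 `COc1cc(/C=C2\C(=O)Nc3ccc(C)cc32)ccc1OCCCN1CCN(c2ncccc2C(F)(F)F)CC1` differs from compound 2 by methyl in place of chloro on an aromatic carbon. For the measured compounds named here, the one measured step concerns chloro for hydrogen at this same place; no step concerns methyl for chloro, so in this assay no step beyond the scatter is expected. Compound 3 is estimated at 2000 nM, range 800 nM to 5000 nM. This amounts to an expected step of a 1.3-fold higher number from compound 2 to compound 3 (0.12 log units; within the scatter).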

Compound 3, half-maximal inhibitory concentration: > 20000 nM
Compound 3 gave a limit, no number; the forecaster's own chance of this, stated with the estimate: 5%; at least 10-fold (1.00 log units) between middle value and limit.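

Position and change: in this assay, swapping chloro for methyl, one heavy atom for one, is not a neutral exchange at this position, with an at least 13-fold higher number from compound 2 to compound 3 (1.11 log units; beyond the scatter). The gain seen on adding chloro therefore does not extend to methyl, and among the three compounds only the chloro compound gives a number rather than a limit. The step from compound 1 to compound 3 cannot be read: the limit of > 20000 nM in this assay, at which 2 of the 3 values shown sit.

Still open, as far as these compounds go, is whether fluoro, bromo or methoxy at this position would give a number, or would stay at the limit. Also open, from the compounds shown here alone, is whether chloro on another carbon of the same ring would behave as it does here.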